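This account rests on a few compounds, and the source may have more. Where it says the series, first, only, none or still open, it means among the compounds named here.

Working notes on the series. All members share one core, seen in compound 1 `O/N=C(/Nc1ccc(Cl)cc1)c1ccc2occc2c1`; in an assay on isolated protein for inhibition of Indoleamine 2,3-dioxygenase 1 (Homo sapiens), read by spectrophotometry (on this read-out lower numbers stand for stronger inhibition and higher numbers for weaker inhibition), compound 1 gives only a limit, > 30000 nM. Compound 2 `O/N=C(/Nc1cccc(F)c1)c1ccc2occc2c1` gives 32700 nM in this assay. Within the data shown here, compound 3 `O/N=C(/Nc1ccc(F)c(F)c1)c1ccc2occc2c1` gives 22700 nM, the lowest of the two numbers so far, though its nearest neighbour is compound 2 and the single measured step, a 1.4-fold lower number from compound 2 to compound 3 (0.16 log units; within the scatter), stays within the scatter. Compound 4 `O/N=C(/Nc1ccc(F)c(C(F)(F)F)c1)c1ccc2occc2c1` differs from compound 3 by trifluoromethyl in place of fluoro on an aromatic carbon. Among the measured compounds shown here, no measured step exchanges a fluoro for a trifluoromethyl, so the only guide is the one substituent step on this ring, from compound 2 to compound 3, which was small. A step of similar size is therefore expected, a 1.1-fold lower number from compound 3 to compound 4 (0.05 log units; within the scatter), with no firm direction. Compound 4 is estimated at about 20000 nM in this assay, between 7000 nM and 60000 nM. A limit reading, as in the limit of > 30000 nM in this assay, at which 1 of the 3 values shown sits, remains a real possibility for compound 4.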

Compound 4, half-maximal inhibitory concentration: 1200 nM
Compound 4: middle estimate off by 17-fold (1.22 log units), on the high side, outside the stated range (below it).
By their numbers in this assay, from the lowest: compound 4; then compounds 3 and 2 (each within the scatter of the next).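

The aromatic carbon ortho to a fluoro group and meta to a large group proves sensitive to its substituent: trifluoromethyl in place of fluoro gives a 19-fold lower number from compound 3 to compound 4 (1.28 log units; beyond the scatter). Among these compounds, the only earlier step on this ring, a 1.4-fold lower number from compound 2 to compound 3 (0.16 log units; within the scatter), gave no sign of a change of this size, so substitution on this ring can move the number well beyond the scatter. Compound 4 also gives a full number, whereas compound 1 remains a limit reading: the limit of > 30000 nM in this assay, at which 1 of the 4 values shown sits.

As far as these compounds go, whether the lower number belongs to trifluoromethyl alone stays open; a methyl, a nitrile or an amine on this same carbon would settle that. Also open, from the compounds shown here alone, is whether the step depends on the fluoro group ortho to it, which a compound with trifluoromethyl as the only substituent on this ring would show.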